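Aryl variation on an aromatic nitrogen of the shared core

The source may hold more compounds than are shown below. What is called first, only, known or untested is meant among the compounds shown, and "the series" means these compounds.

Measured so far in a functional assay on U-87MG ATCC cells (Homo sapiens) for inhibition, read by MTT assay, with a stated time of 72 h; a lower number here means a stronger inhibitor, a higher number a weaker inhibitor:
compound 1, `COc1cc2c(Oc3ccc(NC(=O)c4nn(-c5ccccc5C)c(=O)cc4C)cc3F)ccnc2cc1OCCCN1CCC(C)CC1`, 2240 nM
compound 2, `COc1cc2c(Oc3ccc(NC(=O)c4nn(-c5cccc(F)c5)c(=O)cc4C)cc3F)ccnc2cc1OCCCN1CCC(C)CC1`, 1800 nM

Compound 2 holds the lowest of the two numbers, but the gap to compound 1 is small: a 1.2-fold lower number from compound 1 to compound 2 (0.09 log units; within the scatter), so the two cannot be ordered.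

Compound 3, `COc1ccc(-n2nc(C(=O)Nc3ccc(Oc4ccnc5cc(OCCCN6CCC(C)CC6)c(OC)cc45)c(F)c3)c(C)cc2=O)cc1`, is the next member. The change from compound 2 is 4-methoxyphenyl in place of 3-fluorophenyl on an aromatic nitrogen.

Within the data shown here, only one measured step bears on this change, the exchange of the aryl group on the same aromatic nitrogen from compound 1 to compound 2, and that step stayed within the scatter (a 1.2-fold lower number from compound 1 to compound 2 (0.09 log units; within the scatter)). Among the measured compounds shown here, nothing measured so far separates one aryl group at this place from another beyond the scatter, so for compound 3 a step of no size beyond the scatter is expected in this assay, that is a 1.1-fold higher number from compound 2 to compound 3 (0.02 log units; within the scatter).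

On that basis compound 3 is estimated at 1900 nM, with a range from 800 nM to 4500 nM.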

Compound 3, half-maximal inhibitory concentration: 2840 nM
Compound 3: the middle estimate sits 1.5-fold (0.17 log units) below what was measured; the measured number falls inside the stated range.
By their numbers in this assay, from the lowest: compounds 2, 1 and 3 (each within the scatter of the next).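

With compound 3, the aryl group on the aromatic nitrogen has taken three forms, 2-methylphenyl, 3-fluorophenyl and 4-methoxyphenyl, and in this assay the new pairs stay within the scatter (a 1.6-fold higher number from compound 2 to compound 3 (0.20 log units; within the scatter); a 1.3-fold higher number from compound 1 to compound 3 (0.10 log units; within the scatter)). The entering 4-methoxyphenyl brings a hydrogen-bond acceptor that 3-fluorophenyl lacks, yet this change gives no step beyond the scatter, and compounds 1, 2 and 3 cannot be ordered. Nothing available explains why these numbers lie so close together.

The methyl, fluoro and methoxy groups never share a position number in these names, so the choice of group and its position remain unseparated. Also open, as far as these compounds go, is whether a pyridyl ring, or a plain alkyl chain in place of the aryl group, would give a step beyond the scatter.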